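The source may report more compounds than this note shows. Statements on the series, on what has been measured and on what is new or still open speak of the compounds shown alone.

For the measured compounds named here, compound 2 `O=C(CSc1nnc(-c2ccncc2)o1)N/N=C/c1ccc([N+](=O)[O-])cc1` stands at the higher of the two numbers measured so far in a functional assay on BGC-823 cells (Homo sapiens) for cytotoxicity, read by MTT assay, with a stated time of 48 h; a lower number here means a stronger inhibitor, a higher number a weaker inhibitor; there compound 2 gives 31500 nM. Going by the values given here, its only measured neighbour is compound 1 `NNC(=O)CSc1nnc(-c2ccncc2)o1`, which carries no aryl group on the hydrazide; in this assay compound 1 gives 3260 nM, a markedly lower number, and the gap between the two lies beyond the usual scatter. Compound 3 `O=C(CSc1nnc(-c2ccncc2)o1)N/N=C/c1cccs1` has not yet been tested. It differs from compound 2 in a single place: thiophen-2-yl in place of 4-nitrophenyl on a carbon with a double bond to nitrogen. Among the compounds with values here, no measured pair shows this change, so there is no step to rest on; the expectation can only be that an aryl hydrazone of this kind stays nearer compound 2 than compound 1. Compound 3 is therefore expected to give 15000 nM, with a range from 4000 nM to 50000 nM. The expected step of a 2.1-fold lower number from compound 2 to compound 3 (0.32 log units; beyond the scatter) is estimated to be a modest move to a lower number, of a size barely beyond the scatter.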

Compound 3, half-maximal inhibitory concentration: 26700 nM
Beside the measured number, compound 3's estimate is 1.8-fold (0.25 log units) below it; low and high end bracket the measured number.
By their numbers in this assay, from the lowest: compound 1; then compounds 3 and 2 (each within the scatter of the next).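

In this assay, for the compounds shown here, the exchange of 4-nitrophenyl for thiophen-2-yl on a carbon with a double bond to nitrogen gives a 1.2-fold lower number from compound 2 to compound 3 (0.07 log units; within the scatter) so this change of aromatic ring leaves the number unresolved from that of compound 2, something the earlier compounds could not show. The step of an 8.2-fold higher number from compound 1 to compound 3 (0.91 log units; beyond the scatter) then shows that the large gap from the unsubstituted hydrazide is not confined to the 4-nitrophenyl group but recurs with a five-membered ring carrying sulfur. Nothing shown here gives a reason for either step. From the compounds shown here alone, whether a non-aromatic group such as cyclohexyl or methyl on that carbon would stay with compounds 2 and 3 or come closer to compound 1 remains open. The same question stands for a phenyl ring carrying an amine such as dimethylamino.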